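A few compounds are considered here, and "the series" means these few. Any claim that something is new, unique, unknown or untested is made for them only; others in the source may bear on it.

Measured compounds in a functional assay on BT-20 cells (Homo sapiens) for antiproliferative activity, read by trypan blue exclusion; a lower number here means a stronger inhibitor, a higher number a weaker inhibitor:

Compound 1 `COc1ccc(/C=C/S(=O)(=O)Cc2ccc(OC)cc2)cc1` gives > 20000 nM in this assay, a limit of the assay rather than a number.
Compound 2 `COc1ccc(CS(=O)(=O)/C=C/c2ccc(F)cc2)cc1` gives 1500 nM in this assay.
Compound 3 `COc1ccc(CS(=O)(=O)/C=C/c2ccc(F)cc2OC)cc1` gives 15000 nM in this assay.

Compound 1 sits at the limit (the limit of > 20000 nM in this assay, at which 1 of the 3 values shown sits), so only a bound is known for it. The change from compound 2 to compound 1 is methoxy in place of fluoro on an aromatic carbon; it produced an at least 13-fold higher number from compound 2 to compound 1 (1.12 log units; beyond the scatter). Compound 3 differs from compound 2 by methoxy in place of hydrogen on an aromatic carbon, a step of a 10-fold higher number from compound 2 to compound 3 (1.00 log units; beyond the scatter). Among the two compounds with numbers, compound 3 has the higher one.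

Compound 4 `COc1ccc(CS(=O)(=O)/C=C/c2ccc(OC)cc2OC)cc1` is not yet measured in this assay. It differs from compound 3 by methoxy in place of fluoro on an aromatic carbon. This is the same kind of change as that from compound 2 to compound 1, but the place is not identical: in compound 4 the entering methoxy sits meta to a methoxy group, whereas in compound 1 it sits only para to a large group. Since the earlier instance gave an at least 13-fold higher number from compound 2 to compound 1 (1.12 log units; beyond the scatter), starting from compound 3 with 15000 nM, the number for compound 4 is expected to lie far higher.

Compound 4 is expected to give 80000 nM in this assay, within 20000 nM to 400000 nM, a step of a 5.3-fold higher number from compound 3 to compound 4 (0.73 log units; beyond the scatter) from compound 3, with a high chance that only a limit is reported.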

Compound 4, half-maximal inhibitory concentration: > 20000 nM
Compound 4 ended at the assay's limit; the forecaster's own chance of this, stated with the estimate: 85%; the middle value does not contradict the limit.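

Methoxy in place of fluoro on an aromatic carbon now appears on two cores in this assay, and on the core of compound 3 it gives an at least 1.3-fold higher number from compound 3 to compound 4 (0.12 log units; that floor lies within the scatter), a floor and not a measured size, as compound 4 sits at a limit of the assay. The two instances agree only in that neither shows a lower number after the change, and their sizes cannot be set against each other: the same change on two cores in this assay, an at least 13-fold higher number (1.12 log units; beyond the scatter) from compound 2 to compound 1 and an at least 1.3-fold higher number (0.12 log units; that floor lies within the scatter) from compound 3 to compound 4; the limit leaves it open whether they differ Nothing here shows that the change costs the same on both cores or that a real rise occurs on the core of compound 3, and the step between compound 1 and compound 4 cannot be read, as both compounds sit at the limit: the limit of > 20000 nM in this assay, at which 2 of the 4 values shown sit.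

The aromatic substituents shown are confined to fluoro, methoxy and hydrogen, so it remains open how an amine, a carboxylic acid or a nitrile at the same place would read in this assay. As far as these compounds go, it is equally open whether the fluoro of compound 2 could be replaced by a chloro or a trifluoromethyl group on the shared core while keeping a number clear of the limit.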